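The source may hold more compounds than are shown below. What is called first, only, known or untested is meant among the compounds shown, and "the series" means these compounds.

Measured so far in an ADME assay on L1210/0 cells (Mus musculus) for cytotoxicity, with a stated time of 48 h; on this read-out lower numbers stand for stronger inhibition and higher numbers for weaker inhibition:
Compound 1 `COc1ccccc1-c1ncnc2c1ncn2C[C@@H]1C[C@H](O)c2ccccc21`: > 200000 nM, a limit
Compound 2 `O=c1[nH]c(=O)n([C@@H]2C[C@H](CO)C[C@@H]2CO)cc1I`: > 200000 nM, a limit

Neither compound has given an actual number, so compound 2 cannot be ranked against compound 1. All that can be said is that compound 2 shares (the limit of > 200000 nM in this assay, at which 2 of the 2 values shown sit).

Compound 3 `O=c1ccn([C@@H]2C[C@H](CO)C[C@@H]2CO)c(=O)[nH]1` is compound 2 with one change: hydrogen in place of iodo on an aromatic carbon. For the measured compounds named here, no measured pair shows what this change does. Going by the values given here, the only guide is compound 2, which gives > 200000 nM, a limit of the assay.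

In this assay, no step beyond the usual scatter is expected, in either direction. The expected step, a number no higher from compound 2 to compound 3 (the limit leaves the size open), is an estimate only. For compound 3 the estimated value is 200000 nM, with an expected range from 100000 nM to 400000 nM.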

Compound 3, half-maximal inhibitory concentration: > 200000 nM
Compound 3: only a limit was reported; the forecaster's own chance of this, stated with the estimate: 85%; the middle value sits exactly at the limit.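

Compound 2 and compound 3 both stop at a limit in this assay, so no step can be read for hydrogen in place of iodo: the limit of > 200000 nM in this assay, at which 3 of the 3 values shown sit.

The compounds shown leave open whether this change has any effect in this assay and how strongly any of the three compounds inhibits, as none has given an actual number.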